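Fluorine on a Restored Pyridin-4-yl Arm

The compounds below may be only part of what the source reports. "The series", "measured", "known", "first", "only" and "open" are said of these compounds alone.

Compound 1 `COc1cccc(Cn2cnc3sc(-c4ccncc4)cc3c2=O)c1` gives 45 nM in an assay on isolated protein for inhibition of Rho-associated protein kinase 1 (Homo sapiens), read by radiometric assay and 33P incorporation, with a stated time of 40 min, in the presence of a further agent that is not named here; a higher number here means a weaker inhibitor, a lower number a stronger inhibitor. Compound 2 `COc1cccc(Cn2cnc3sc(-c4cccnc4)cc3c2=O)c1` gives > 10000 nM in this assay, and that figure is a limit of the assay, not a number (the limit of > 10000 nM in this assay, at which 1 of the 2 values shown sits). Compound 2 thus sits at the weak end of what is shown. The step of an at least 220-fold higher number from compound 1 to compound 2 (2.34 log units; beyond the scatter) is large and beyond the scatter. Compound 3 `COc1cccc(Cn2cnc3sc(-c4ccnc(F)c4)cc3c2=O)c1` reverses that change and adds a fluorine: 2-fluoropyridin-4-yl in place of pyridin-3-yl on an aromatic carbon. Going by the values given here, since the only measured step bearing on this move is that from compound 1, a large fall in the number is expected, an at least 40-fold lower number from compound 2 to compound 3 (1.60 log units; beyond the scatter). Compound 3 is estimated at 250 nM, within 40 nM to 2500 nM.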

Compound 3, half-maximal inhibitory concentration: 1050 nM
Beside the measured number, compound 3's estimate is 4.2-fold (0.62 log units) below it; low and high end bracket the measured number.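

The 2-fluoropyridin-4-yl group gives a measurable number at this position next to the ring sulfur where pyridin-3-yl does not, with an at least 9.5-fold lower number from compound 2 to compound 3 (0.97 log units; beyond the scatter), and this step is read against a limit of the assay for compound 2: the limit of > 10000 nM in this assay, at which 1 of the 3 values shown sits. Yet the arm does not accept the added fluorine without loss, with a 23-fold higher number from compound 1 to compound 3 (1.37 log units; beyond the scatter). So this arm responds to a single fluoro in place of hydrogen, not only to pyridin-3-yl in place of pyridin-4-yl. The compounds shown leave open whether a methyl, a chlorine or an amine in place of that fluorine would cost as much.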